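Moving the two fluorines on the acyl ring of compound 2

The source may hold more compounds than are shown below. What is called first, only, known or untested is meant among the compounds shown, and "the series" means these compounds.

Among the measured compounds shown here, compound 2 `CN(C(=O)NC(=O)c1ccc(F)c(F)c1)c1nc(C(F)(F)F)c(C(=O)N/N=C/c2cc(C(F)(F)F)cc(C(F)(F)F)c2)s1` gives the lowest of the three numbers so far in a functional assay on A549 cells (Homo sapiens) for inhibition, read by MTT assay, with a stated time of 72 h (on this read-out lower numbers stand for stronger inhibition and higher numbers for weaker inhibition), at 5.47 ug/mL, though it is within the scatter of both its neighbours. Compound 3 `CN(C(=O)NC(=O)c1ccc(F)c(F)c1)c1nc(C(F)(F)F)c(C(=O)N/N=C/c2cccc(C(F)(F)F)c2)s1` gives 6.52 ug/mL in this assay, and compound 1 `CN(C(=O)NC(=O)c1ccc(F)c(F)c1)c1nc(C(F)(F)F)c(C(=O)N/N=C/c2ccccc2C(F)(F)F)s1` gives 6.96 ug/mL. The two measured steps both touch the other aryl ring of the shared core: a 1.1-fold lower number from compound 1 to compound 3 (0.03 log units; within the scatter) and a 1.2-fold higher number from compound 2 to compound 3 (0.08 log units; within the scatter), neither of them beyond the scatter.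

Compound 4 `CN(C(=O)NC(=O)c1c(F)cccc1F)c1nc(C(F)(F)F)c(C(=O)N/N=C/c2cc(C(F)(F)F)cc(C(F)(F)F)c2)s1` differs from compound 2 elsewhere: 2,6-difluorophenyl in place of 3,4-difluorophenyl on a carbonyl carbon. For the measured compounds named here, no measured step bears on this part of the molecule, so the two steps above say only that the series has so far been flat within the scatter, and nothing about the acyl ring. Going by the values given here, with no direct precedent, the expected step from compound 2 to compound 4 in this assay is a 1.1-fold higher number from compound 2 to compound 4 (0.04 log units; within the scatter), that is, none beyond the scatter, with a wider range than usual to allow for the untested position. Compound 4 is therefore estimated at 6 ug/mL in this assay, with a range from 3 ug/mL to 14 ug/mL.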

Compound 4, half-maximal inhibitory concentration: 17.3 ug/mL
For compound 4 the middle estimate is 2.9-fold (0.46 log units) below the measured one; the whole stated range lies below it.
By their numbers in this assay, from the lowest: compounds 2, 3 and 1 (each within the scatter of the next); then compound 4.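

Among the compounds shown here, the acyl ring is the first place where a change moves the number beyond the scatter in this assay: 2,6-difluorophenyl in place of 3,4-difluorophenyl on a carbonyl carbon gives a 3.2-fold higher number from compound 2 to compound 4 (0.50 log units; beyond the scatter), a modest step towards weaker inhibition. Both groups have the same heavy atoms, the same ring and the same counts of donors and acceptors, so the step comes with a rearrangement of the two fluorines alone, while the steps measured on the other aryl ring all stayed within the scatter. No measurement at hand bears on why this rearrangement carries the step.

This position is read through a single pair, so the compounds shown leave open whether the same exchange would give a similar step with the aryl rings of compound 1 or compound 3, or whether it is particular to the ring of compound 2. They also leave open which of the two fluorines matters, and how the series would respond to a plain phenyl ring, a pyridine ring or chlorine in place of fluorine on the acyl ring.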